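Changing One Side Group in a Low-Toxicity Series

The source may report more compounds than this note shows. Statements on the series, on what has been measured and on what is new or still open speak of the compounds shown alone.

Measured compounds:
- Compound 1, `CNc1nc(N)nc2c1ncn2/C=C1/CC1(CO)CO`: in an ADME assay on HFF cells (Homo sapiens) for cytotoxicity, with a stated time of 8 days (on this read-out lower numbers stand for higher toxicity in this test and higher numbers for lower toxicity in this test), compound 1 gives 265000 nM.
- Compound 2, `CC(C)CSc1nc(N)nc2c1ncn2/C=C1/CC1(CO)CO`: compound 2 gives > 300000 nM, which is a limit of the assay rather than a number.
- Compound 3, `C=CCOc1nc(N)nc2c1ncn2/C=C1/CC1(CO)CO`: compound 3 gives > 300000 nM, again a limit of the assay and not a number.

Compound 2 therefore stands at the limit of > 300000 nM in this assay, at which 2 of the 3 values shown sit. Compound 4, `Nc1nc(OCc2ccccc2)c2ncn(/C=C3/CC3(CO)CO)c2n1`, is not yet measured; it differs from compound 2 as follows: benzyloxy in place of isobutylsulfanyl on an aromatic carbon.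

Among the measured compounds shown here, three measured steps bear on this change. There is an at least 1.1-fold higher number from compound 1 to compound 2 (0.05 log units; that floor lies within the scatter) and an at least 1.1-fold higher number from compound 1 to compound 3 (0.05 log units; that floor lies within the scatter); both are floors set by the limit and neither shows a real change. There is also a step that the two limits leave unreadable from compound 2 to compound 3, so the swap of one such side group for another gave no readable step. All three compounds show little toxicity in this assay, and nothing among them points to a step beyond the scatter when a benzyloxy group takes the place of the isobutylsulfanyl group.

Compound 4 is therefore expected to give 300000 nM, between 120000 nM and 700000 nM, which would mean the estimated step of a number no higher from compound 2 to compound 4 (the limit leaves the size open).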

Compound 4, half-maximal cytotoxic concentration: > 300000 nM
Compound 4 was reported as a limit (the forecaster's own chance of this, stated with the estimate: 65%); the middle value sits exactly at the limit.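

Compound 4 carries the first side group here with a ring, a benzyloxy group holding a six-membered aromatic ring of carbon only, and in this assay it too gives a limit and not a number: the limit of > 300000 nM in this assay, at which 3 of the 4 values shown sit.

Among the compounds shown here, the only step that can be read is an at least 1.1-fold higher number from compound 1 to compound 4 (0.05 log units; that floor lies within the scatter), and it is a floor set by the limit, not a real change. The steps that link compound 4 to compound 2 and to compound 3 cannot be read, since both ends of each are limits.

On these data alone, the true values behind these limits stay unknown, so the three side groups cannot be ranked against one another. As far as these compounds go, whether a carboxylic acid or a longer chain at this position would give a real number in this test also stays open.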